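A few compounds are considered here, and "the series" means these few. Any claim that something is new, unique, unknown or untested is made for them only; others in the source may bear on it.

Measured compounds:
compound 1 `COc1ccc(NC(=O)CCc2cccc3c2B(O)OC3)cc1` gives > 100000 nM in an ADME assay on WI-38 cells (Homo sapiens) for cytotoxicity, read by MTT assay, with a stated time of 72 h; on this read-out lower numbers stand for stronger inhibition and higher numbers for weaker inhibition;
compound 2 `COc1ccc(NC(=O)CCc2cccc3c2B(O)OC3)cc1OC` gives > 100000 nM in this assay;
compound 3 `COc1cccc(-c2cccc(NC(=O)CCc3ccc4c(c3)B(O)OC4)c2)c1` gives > 100000 nM in this assay.

Each of these three values is a limit of this assay, not a number. For compound 1 the value > 100000 nM is a limit. For compound 2 the value > 100000 nM is also a limit. For compound 3 the value > 100000 nM is again a limit, and the two other values shown beside it are limits as well. All three sit at the limit of > 100000 nM in this assay, at which 3 of the 3 values shown sit.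

Compound 1 and compound 2 differ by methoxy in place of hydrogen on an aromatic carbon. The resulting step that the two limits leave unreadable from compound 1 to compound 2 cannot be read in size, because both ends are limits.

The unmeasured compound 4 `COc1cc(OC)cc(-c2cccc(NC(=O)CCc3ccc4c(c3)B(O)OC4)c2)c1` differs from compound 3 by methoxy in place of hydrogen on an aromatic carbon. The difference between the two cores of compound 1 and compound 3 is not broken down here. The change in compound 4 is the same kind of change as that from compound 1 to compound 2, but its surroundings differ: in compound 2 the new methoxy sits ortho to a methoxy group and meta to a large group, whereas in compound 4 it sits meta to a large group and meta to a methoxy group.

For compound 4 the expected step is a step that the limit leaves unreadable from compound 3 to compound 4, resting on compound 3 and its value > 100000 nM together with the limit of > 100000 nM in this assay, at which 3 of the 3 values shown sit. Compound 4 is therefore estimated at 120000 nM, with an expected range from 50000 nM to 300000 nM, most likely reported as a limit once more.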

Compound 4, half-maximal inhibitory concentration: > 100000 nM
Compound 4 was reported as a limit; the forecaster's own chance of this, stated with the estimate: 85%; the middle value lies beyond the limit too.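

In this assay compound 4 gives > 100000 nM as a limit of the assay, not a number. No step can be read from compound 3 to compound 4, because both ends are limits: the limit of > 100000 nM in this assay, at which 4 of the 4 values shown sit. The compounds shown leave open how far any of them lies from that limit, and whether methoxy in place of hydrogen on an aromatic carbon changes this read-out at all.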